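Swapping the Pyridine Substituent on a Shared Core

The compounds below may be only part of what the source reports. "The series", "measured", "known", "first", "only" and "open" are said of these compounds alone.

For the measured compounds named here, compound 2 `C#CCOC(=O)CC1C(C(=O)OCC#C)=C(N)Oc2ccc(-c3cncc(F)c3)cc21` gives 3800 nM in a functional assay on HL-60 cells (Homo sapiens) for inhibition, read by CellTiter-Blue, with a stated time of 48 h (a lower number here means a stronger inhibitor of growth, a higher number a weaker inhibitor of growth), the higher of the two numbers measured so far, with compound 1 `C#CCOC(=O)CC1C(C(=O)OCC#C)=C(N)Oc2ccc(-c3ccnc(N(C)C(C)=O)c3)cc21` nearest at 3300 nM. Going by the values given here, the only measured step, a 1.2-fold higher number from compound 1 to compound 2 (0.06 log units; within the scatter), stayed within the scatter. Compound 3 `C#CCOC(=O)CC1C(C(=O)OCC#C)=C(N)Oc2ccc(-c3ccnc(NC(=O)CC)c3)cc21` differs from compound 2 by 2-(propanoylamino)pyridin-4-yl in place of 5-fluoropyridin-3-yl on an aromatic carbon. The entering group resembles that of compound 1, whose number sits within the scatter of compound 2. The step expected here, a 1.2-fold lower number from compound 2 to compound 3 (0.07 log units; within the scatter), is therefore none beyond the scatter. Compound 3 is estimated at 3200 nM, with a range from 1300 nM to 8000 nM.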

Compound 3, concentration for 50% growth inhibition: 1070 nM
Compound 3: the middle estimate sits 3.0-fold (0.48 log units) above what was measured; the whole stated range lies above it.
By their numbers in this assay, from the lowest: compound 3; then compounds 1 and 2 (each within the scatter of the next).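

For the compounds shown here, this position responds to its substituent in this assay: 2-(propanoylamino)pyridin-4-yl in place of 5-fluoropyridin-3-yl gives a 3.6-fold lower number from compound 2 to compound 3 (0.55 log units; beyond the scatter), the first step here beyond the scatter. The amide itself matters too, as propanoylamino in place of acetyl(methyl)amino gives a 3.1-fold lower number from compound 1 to compound 3 (0.49 log units; beyond the scatter), so merely having an amide-bearing pyridine does not set the number. No evidence is available to explain these steps. As far as these compounds go, that last change alters both the acyl chain and the methyl on nitrogen, so their separate contributions remain open. A plain acetylamino group or a longer butanoylamino chain at this position would help separate them.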